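Swapping a Phenyl Ring for Thiophene on a Boronate

A few compounds are considered here, and "the series" means these few. Any claim that something is new, unique, unknown or untested is made for them only; others in the source may bear on it.

Of the compounds shown here, three have been measured in an assay on HUVEC cells for inhibition of endothelial lipase (Homo sapiens), with a stated time of 10 min; on this read-out higher numbers stand for weaker inhibition and lower numbers for stronger inhibition. Compound 1 `CCCc1ccc(B2OC(C)(C)C(C)(C)O2)cc1` gives 6000 nM. Compound 2 `CCCCCCCCCc1ccc(B2OC(C)(C)C(C)(C)O2)cc1` gives 1000 nM, and compound 3 `CC1(C)OB(c2ccc(-c3ccccc3)cc2)OC1(C)C` gives 1000 nM. Two single-point steps connect them: a 6.0-fold lower number from compound 1 to compound 2 (0.78 log units; beyond the scatter) and a 6.0-fold lower number from compound 1 to compound 3 (0.78 log units; beyond the scatter). Compound 3 therefore shares the lowest number of the set with compound 2, the two values sitting level within the scatter, while compound 1 stands clearly apart from both.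

Compound 4 `CC1(C)OB(c2ccc(-c3ccsc3)cc2)OC1(C)C` differs from compound 3 in one place: thiophen-3-yl in place of phenyl on an aromatic carbon. Going by the values given here, none of the measured steps swaps one aromatic ring for another. The step from compound 1 to compound 3 shows that a phenyl ring in this position is favoured over a propyl chain, but it says nothing about how a thiophene ring compares with phenyl. The incoming ring is likewise aromatic and occupies the same position, so the most defensible expectation is a change that stays within the scatter, with a wide range to reflect the absence of a guiding step. Compound 4 is expected to give about 1500 nM, within 500 nM to 5000 nM. This estimate corresponds to a 1.5-fold higher number from compound 3 to compound 4 (0.18 log units; within the scatter), a step expected to fall within the usual scatter.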

Compound 4, half-maximal inhibitory concentration: 3100 nM
Compound 4: middle estimate off by 2.1-fold (0.32 log units), on the low side; the measured number falls inside the stated range.
By their numbers in this assay, from the lowest: compounds 2 and 3 (each within the scatter of the next); then compounds 4 and 1 (each within the scatter of the next).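

In this assay the swap of phenyl for thiophen-3-yl gives a 3.1-fold higher number from compound 3 to compound 4 (0.49 log units; beyond the scatter) and so shows that two aromatic rings on the same aromatic carbon are not interchangeable here: the step is modest, but it lies beyond the scatter. Set against the propyl chain, thiophen-3-yl gives a 1.9-fold lower number from compound 1 to compound 4 (0.29 log units; within the scatter) and thus does not separate from propyl on this read-out, whereas phenyl does, so being an aromatic ring is not enough on its own to match compound 3. Nothing available explains why the five-membered ring with its sulfur atom and the six-membered carbon ring part ways at this position.

The compounds shown leave open whether this result is specific to thiophen-3-yl or extends to other rings, such as thiophen-2-yl, furan or pyridine, which would show whether the attachment point, the hetero atom or the ring size matters most. They also leave open whether adding a small group such as methoxy or fluorine to the phenyl ring of compound 3 would take the number lower still or raise it.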